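The source may report more compounds than this note shows. Statements on the series, on what has been measured and on what is new or still open speak of the compounds shown alone.

In an ADME assay on microsomes from liver (Rattus norvegicus) for metabolic stability, using NADPH (on this read-out lower numbers stand for slow clearance and higher numbers for fast clearance), two compounds have numbers so far:

Compound 1 `CNC(=O)c1nc(Br)c(C(F)(F)F)cc1N` gives 0.1 mL/min/kg
Compound 2 `C[C@](O)(CNC(=O)c1nc(C(F)(F)F)c(C(F)(F)F)cc1N)C(F)(F)F` gives 0.00738 mL/min/kg

Compound 2 at 0.00738 mL/min/kg holds the lower of the two numbers, and compound 1 at 0.1 mL/min/kg stands higher by more than the usual scatter. Compound 3 `CCOc1nc(C(=O)NC[C@](C)(O)C(F)(F)F)c(N)cc1C(F)(F)F` has not yet been measured. It differs from compound 2 in one place ethoxy in place of trifluoromethyl on an aromatic carbon with ethoxy in place of trifluoromethyl on an aromatic carbon, next to the ring nitrogen and para to an amino group. Going by the values given here, no two measured compounds differ in one place alone, so the data offer no direct guide to this exchange. With compound 2 at 0.00738 mL/min/kg as the lowest number seen so far, a further fall in this assay looks less likely than a rise. A moderate rise beyond the scatter is therefore expected, though its size is uncertain. The expected step of a 5.4-fold higher number from compound 2 to compound 3 (0.73 log units; beyond the scatter) reflects that view. For compound 3 the estimated clearance is 0.04 mL/min/kg with an expected range from 0.008 mL/min/kg to 0.2 mL/min/kg as the likely span of a measurement.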

Compound 3, clearance in the Rattus norvegicus assay: 0.039 mL/min/kg
Compound 3: middle estimate off by 1.0-fold (0.01 log units), on the high side, and the stated range covers the measured number.
By their numbers in the Rattus norvegicus assay, from the lowest: compound 2; then compound 3; then compound 1.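

Going by these compounds alone, in the Rattus norvegicus assay compound 2 gives 0.00738 mL/min/kg and compound 3 gives 0.039 mL/min/kg; the exchange of trifluoromethyl for ethoxy on the aromatic carbon next to the ring nitrogen and para to an amino group gives the only direct reading of a single change in this set, a 5.3-fold higher number from compound 2 to compound 3 (0.72 log units; beyond the scatter), so clearance at this position does respond to the group placed there, though the step is modest. Within the data shown here, in a physicochemical assay for solubility, at pH 6.8 (a lower number here means a less soluble compound, a higher number a more soluble compound), compound 2 gives 82 ug/mL and compound 3 gives 60 ug/mL; the same exchange gives a 1.4-fold lower number from compound 2 to compound 3 (0.14 log units; within the scatter), so on solubility compound 2 and compound 3 cannot be told apart, and the change that shows in clearance has no counterpart in this read-out. No measurement presented here bears on what lies behind the step in clearance.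

A single pair cannot show whether the step belongs to ethoxy in particular or to the departure of trifluoromethyl, and compound 1, which carries bromine at this place, differs from the others in more than one place and so offers no comparison. From the compounds shown here alone, how methoxy, a longer ether such as propoxy, or an amine on this same carbon would stand in either assay remains open.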